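This account rests on a few compounds, and the source may have more. Where it says the series, first, only, none or still open, it means among the compounds named here.

Measured so far in a functional assay on U-251 cells (Homo sapiens) for inhibition, read by MTT assay, with a stated time of 2 days; a higher number here means a weaker inhibitor of growth, a lower number a stronger inhibitor of growth:
compound 1 `Nc1ccccc1NC(=O)CCCNCC(=O)Nc1ccc(Cl)cc1`: 75000 nM
compound 2 `Nc1ccccc1NC(=O)CCCNCC(=O)Nc1cc(Cl)ccc1Cl`: > 100000 nM

For compound 2, > 100000 nM is a limit of the assay and not a number. This is the limit of > 100000 nM in this assay, at which 1 of the 2 values shown sits, so compound 2 has no exact place in the series.

Compound 3 `Nc1ccccc1NC(=O)CCCNCC(=O)Nc1ccccc1Cl` has 2-chlorophenyl where compound 2 has 2,5-dichlorophenyl: hydrogen in place of chloro on an aromatic carbon. In words, hydrogen stands in place of chloro on an aromatic carbon. For the measured compounds named here, only one measured step bears on this change: an at least 1.3-fold higher number from compound 1 to compound 2 (0.12 log units; that floor lies within the scatter). That step is a different change on the same amide-type nitrogen, and its floor stays within the scatter, so it gives only weak guidance on size and direction. Compound 3 has a single chloro group, as does compound 1, which gives 75000 nM. That value is therefore the main anchor for the expectation in this assay. The expected change is a small move toward a lower number, an at least 1.2-fold lower number from compound 2 to compound 3 (0.09 log units; that floor lies within the scatter), and it may not exceed the scatter. Compound 3 is estimated at 80000 nM, with an expected range of 40000 nM to 100000 nM.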

Compound 3, concentration for total growth inhibition: > 100000 nM
Compound 3: only a limit was reported (the forecaster's own chance of this, stated with the estimate: 35%); middle value at least 1.2-fold (0.09 log units) from the limit.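

In this assay compound 3 gives > 100000 nM, which is a limit of the assay and not a number, and the step from compound 2 to compound 3 cannot be read, as both compounds stand at the same limit: the limit of > 100000 nM in this assay, at which 2 of the 3 values shown sit.

Taking one chloro group off the 2,5-dichlorophenyl therefore gives no measurable gain, so the hydrogen in place of chloro on this aromatic carbon has no readable effect in this assay. The new comparison with a single chloro group on each ring, 2-chlorophenyl in place of 4-chlorophenyl, gives an at least 1.3-fold higher number from compound 1 to compound 3 (0.12 log units; that floor lies within the scatter), so no difference between these two placements of chloro is established.

Compound 1 remains the only compound here with an exact value, and the compounds shown leave open whether that value depends on the chloro group at all. A plain phenyl, or a methoxy group or an amine in place of the chloro group of compound 1, would test this, while a longer chain in the core would show whether any readable change comes from elsewhere in the molecule.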